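Replacing the chlorophenyl with a hydroxymethoxyphenyl

The compounds below may be only part of what the source reports. "The series", "measured", "known", "first", "only" and "open" are said of these compounds alone.

Compound 2 `CN(C)CCn1cnnc1-c1cc(Oc2ccc(NC(=O)N/N=C/c3ccc(Cl)cc3)cc2F)ccn1` gives 1370 nM in a functional assay on U-87MG ATCC cells (Homo sapiens) for cytotoxicity, read by MTT assay, with a stated time of 72 h (a lower number here means a stronger inhibitor, a higher number a weaker inhibitor), while compound 1 `CN(C)CCn1cnnc1-c1cc(Oc2ccc(NC(=O)N/N=C/c3ccc(F)cc3)cc2F)ccn1` gives 2310 nM. Compound 2 carries the lowest of the two numbers, yet the step of a 1.7-fold lower number from compound 1 to compound 2 (0.23 log units; within the scatter) stays within the scatter. Compound 3 `COc1cc(/C=N/NC(=O)Nc2ccc(Oc3ccnc(-c4nncn4CCN(C)C)c3)c(F)c2)ccc1O` differs from compound 2 by 4-hydroxy-3-methoxyphenyl in place of 4-chlorophenyl on a carbon with a double bond to nitrogen. Going by the values given here, no measured step covers such a change; the single step known, a chloro in place of a fluoro, was small. The step is therefore expected to be a 1.5-fold higher number from compound 2 to compound 3 (0.16 log units; within the scatter), not clearly beyond the scatter. Compound 3 is estimated at 2000 nM, within a range of 700 nM to 6000 nM.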

Compound 3, half-maximal inhibitory concentration: > 100000 nM
Compound 3 ended at the assay's limit (the forecaster's own chance of this, stated with the estimate: 5%); middle value at least 50-fold (1.69 log units) away from the limit.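

In this assay, this position proves far more sensitive to the aryl group than the chloro-for-fluoro exchange suggested, which gave a 1.7-fold lower number from compound 1 to compound 2 (0.23 log units; within the scatter). With 4-hydroxy-3-methoxyphenyl on the carbon with a double bond to nitrogen, the steps are an at least 72-fold higher number from compound 2 to compound 3 (1.86 log units; beyond the scatter) and an at least 43-fold higher number from compound 1 to compound 3 (1.63 log units; beyond the scatter). The value of compound 3 is a limit of the assay, not a number: the limit of > 100000 nM in this assay, at which 1 of the 3 values shown sits.

The compounds shown leave open which of the hydroxy and methoxy groups, entering together, goes with this step. They also leave open how a phenyl carrying an amine or a carboxylic acid would read at this position.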